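The compounds below may be only part of what the source reports. "The series", "measured", "known", "first", "only" and "open" are said of these compounds alone.

Working notes. Compound 1 `CCN(CC)CN1C(=O)/C(=N/NC(N)=S)c2cc(Cl)ccc21` is the parent of the pair measured so far. In an ADME assay on HEL cells (Homo sapiens) for cytotoxicity (a lower number here means that less compound is tolerated, a higher number that more compound is tolerated), compound 1 reaches only a limit, > 100000 nM. Compound 2 `CCN(CC)CN1C(=O)/C(=N/NC(=S)Nc2ccc(Cl)cc2)c2cc(Cl)ccc21` carries a 4-chlorophenyl in place of hydrogen on an amide-type nitrogen, and in this assay compound 2 gives 100000 nM. Within the data shown here, the step of a number no higher from compound 1 to compound 2 (the limit leaves the size open) cannot be sized because compound 1 sits at the limit of > 100000 nM in this assay, at which 1 of the 2 values shown sits; it shows only that the number did not rise. Among the measured compounds shown here, compound 1 therefore stands at a limit, not at a number, and the one step recorded from it leaves its size open. Compound 3 `CCN(CC)CN1C(=O)/C(=N/NC(N)=S)c2ccccc21` differs from compound 1 by hydrogen in place of chloro on an aromatic carbon. For the measured compounds named here, no measured step concerns an aromatic carbon of the shared core, so the sole measured step is a weak guide. No shift beyond the scatter in this assay is expected, and the estimated step is a number no higher from compound 1 to compound 3 (the limit leaves the size open). Compound 3 is expected to give 100000 nM, with a range from 50000 nM to 200000 nM.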

Compound 3, minimum cytotoxic concentration: > 100000 nM
Compound 3: only a limit was reported (the forecaster's own chance of this, stated with the estimate: 60%); the middle value lies on the limit itself.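

Compound 1 and compound 3 both stop at a limit in this assay, so no step between them can be read: the limit of > 100000 nM in this assay, at which 2 of the 3 values shown sit.

Going by these compounds, whether hydrogen in place of chloro on this aromatic carbon shifts the number in this assay remains open, as do the actual values of compound 1 and compound 3.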